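Swapping a methyl for a phenyl on the ring nitrogen

The compounds below may be only part of what the source reports. "The series", "measured", "known", "first", "only" and "open" are said of these compounds alone.

The compounds here share a six-membered non-aromatic ring with one nitrogen, carrying two phenyl groups. Compound 1 `O=C1NC(=O)C(c2ccccc2)CC1c1ccccc1` carries a hydrogen on the amide-type nitrogen in the ring; in a functional assay on the whole organism (strain Swiss albino) for inhibition, with Mus musculus as the target, in the maximal electroshock model, with a stated time of 2 h, at a dose of 25 mg/kg by the intraperitoneal route (on this read-out lower numbers stand for less inhibition and higher numbers for more inhibition at the one dose given (going by the name of the read-out)), compound 1 gives 70.2%. Compound 2 `CN1C(=O)C(c2ccccc2)CC(c2ccccc2)C1=O` carries a methyl there instead, and in this assay compound 2 gives 69.1%. The step of a number 1.1 percentage points lower from compound 1 to compound 2 (within the scatter) shows that this exchange left the read-out essentially unchanged. Among the two measured values, compound 2 holds the lower number, but it lies within the scatter of compound 1, so no order between them can be claimed.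

Compound 3 `O=C1C(c2ccccc2)CC(c2ccccc2)C(=O)N1c1ccccc1` differs from compound 2 in one place: phenyl in place of methyl on an amide-type nitrogen in a ring. Going by the values given here, the only measured step that bears on this position is the one from hydrogen to methyl, which stayed within the scatter; nothing measured covers a phenyl at this nitrogen, so the expectation is uncertain. A step of a number 7.1 percentage points lower from compound 2 to compound 3 (within the scatter) is expected, with no clear direction beyond the scatter. Compound 3 is therefore estimated at 62%, ranging from 35% to 85% in this assay.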

Compound 3, a percentage reported as inhibition, in the whole organism at one dose (the size of the read-out at that dose, not a potency): 38.3%
Compound 3: middle estimate off by 23.7 percentage points, on the high side; measured number inside the range.
By their numbers in this assay, from the lowest: compound 3; then compounds 2 and 1 (each within the scatter of the next).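

The exchange at this nitrogen matters after all. In this assay the earlier swap of hydrogen for methyl stayed within the scatter, whereas phenyl in place of methyl gives a number 30.8 percentage points lower from compound 2 to compound 3 (beyond the scatter) and so reveals a clear sensitivity to the group placed here. Phenyl in place of hydrogen points the same way with a number 31.9 percentage points lower from compound 1 to compound 3 (beyond the scatter), so among the three groups shown, hydrogen and methyl stand together and phenyl stands apart. Nothing available here explains why the read-out falls with phenyl at this position.

With only hydrogen, methyl and phenyl on this nitrogen, the compounds shown leave open how an ethyl group, a longer chain, a benzyl group or a phenyl ring carrying an amine or a carboxylic acid would read, and so whether the read-out falls gradually or abruptly on the way from methyl to phenyl. A single dose and a single time also leave open whether compound 3 would match compound 2 at a higher dose or at another time point.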